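Half-life series, compounds 1 to 4: fluoro for hydrogen

The source may report more compounds than this note shows. Statements on the series, on what has been measured and on what is new or still open speak of the compounds shown alone.

Compound 1 `C=CC(=O)N1CC(NC(=O)Cn2c(C)c(C(=O)N3CCc4c(cccc4OC)C3)c3cc(Br)cc(C)c32)C1` gives 1.67 h in a physicochemical assay for pharmacokinetics, read by LC-MS, in phosphate buffer, at pH 7.4, in the presence of a further agent that is not named here; a higher number here means that the compound lasts longer, a lower number that the compound disappears faster.
Compound 2 `C=CC(=O)N1CC(NC(=O)Cn2cc(C(=O)N3CCc4ccccc4C3)c3cc(Br)ccc32)C1` gives 1.67 h in this assay.
Compound 3 `C=CC(=O)N1CC(NC(=O)Cn2ccc3cc(Br)ccc32)C1` gives 1.67 h in this assay.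

Compound 2 stands level with compounds 1 and 3 at the digits shown in this assay: against compound 1, its nearest, no change at those digits, and against compound 3, its furthest, likewise none; all three lie within the scatter of each other.

Compound 4 `C=CC(=O)N1CC(NC(=O)Cn2cc(C(=O)N3CCc4cc(F)ccc4C3)c3cc(Br)ccc32)C1` awaits this assay. It differs from compound 2 by fluoro in place of hydrogen on an aromatic carbon. For the measured compounds named here, no step between measured compounds isolates a single change, so the measured set gives no direct gauge of this one. In this assay the expected step is no change at the digits printed from compound 2 to compound 4 (within the scatter), none beyond the scatter. Compound 4 is estimated at 1.67 h, between 0.9 h and 3.2 h.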

Compound 4, half-life: 1.67 h
For compound 4 middle estimate and measured number coincide at the digits printed; the range from low to high includes it.
By their numbers in this assay, from the lowest: compounds 1, 2, 3 and 4 (each within the scatter of the next).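

In this assay the exchange of hydrogen for fluoro reads no change at the digits printed from compound 2 to compound 4 (within the scatter) and is the only single-place step shown. It gives the first direct gauge at this aromatic carbon, and the half-life stays within the scatter when 1,2,3,4-tetrahydroisoquinolin-2-yl becomes 6-fluoro-1,2,3,4-tetrahydroisoquinolin-2-yl. No supporting data offer a reason for this result.

One fluoro group at one carbon says nothing about other substituents. From the compounds shown here alone, a methoxy group, an amine or a carboxylic acid at this carbon remains open, as does fluoro at the other carbons of this ring.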